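The source may report more compounds than this note shows. Statements on the series, on what has been measured and on what is new or still open speak of the compounds shown alone.

In a functional assay on HeLa cells (Homo sapiens) for antiproliferative activity, with a stated time of 24 h (on this read-out lower numbers stand for stronger inhibition and higher numbers for weaker inhibition), compound 2 `NC(=O)c1c(NC(=O)c2ccccc2Br)sc2c1CCN(C(=S)Nc1ccccc1C(F)(F)F)C2` gives 39600 nM, and compound 1 `NC(=O)c1c(NC(=O)c2ccccc2Br)sc2c1CCN(C(=S)Nc1ccccc1Br)C2` gives 24700 nM; the two values lie close together, the step of a 1.6-fold higher number from compound 1 to compound 2 (0.20 log units; within the scatter) being within the scatter. Compound 3 `Cc1ccccc1C(=O)Nc1sc2c(c1C(N)=O)CCN(C(=S)Nc1ccccc1C(F)(F)F)C2` differs from compound 2 by methyl in place of bromo on an aromatic carbon. For the measured compounds named here, no measured step bears on the group on the (2-bromophenyl)carbonyl part; the only step known, a 1.6-fold higher number from compound 1 to compound 2 (0.20 log units; within the scatter), concerns the other ring and stayed within the scatter. For compound 3 in this assay the step of a 1.0-fold higher number from compound 2 to compound 3 (0.00 log units; within the scatter) is therefore expected to stay within the scatter, and compound 3 is estimated at 40000 nM, with a range from 15000 nM to 110000 nM.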

Compound 3, half-maximal inhibitory concentration: > 50000 nM
Compound 3 gave a limit, no number (the forecaster's own chance of this, stated with the estimate: 15%); middle value at least 1.2-fold (0.09 log units) from the limit.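

In this assay compound 3 gives > 50000 nM, which is a limit of the assay and not a number. For the compounds shown here, this is the first reading at the (2-bromophenyl)carbonyl part, where methyl in place of bromo gives an at least 1.2-fold higher number from compound 2 to compound 3 (0.10 log units; that floor lies within the scatter). So this change shows only a floor, and its true size cannot be read from the one value capped in this way: the limit of > 50000 nM in this assay, at which 1 of the 3 values shown sits.

The compounds shown leave open how an amine, a methoxy group or a carboxylic acid on this aromatic carbon would read. They also leave open whether the same change would read alike with bromo rather than trifluoromethyl on the other ring.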